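From 4-nitrophenyl to methyl on a carbonyl carbon

The source may hold more compounds than are shown below. What is called first, only, known or untested is meant among the compounds shown, and "the series" means these compounds.

- Compound 1 `COC(=O)c1ccc(C(=O)Nc2cccc3c2N(S(=O)(=O)c2ccc(OC)cc2)CC3)cc1`: 312 nM
- Compound 2 `COc1ccc(S(=O)(=O)N2CCc3cccc(NC(=O)c4ccc([N+](=O)[O-])cc4)c32)cc1`: 95 nM
- Compound 3 `COc1ccc(S(=O)(=O)N2CCc3cccc(NC(=O)c4ccc(F)cc4)c32)cc1`: 45 nM

In a functional assay on MKN-45 cells (Homo sapiens) for cytotoxicity (a lower number here means a stronger inhibitor, a higher number a weaker inhibitor), compound 2 sits in the middle of the three at 95 nM. Compound 4 `COc1ccc(S(=O)(=O)N2CCc3cccc(NC(C)=O)c32)cc1` differs from it in one place (methyl in place of 4-nitrophenyl on a carbonyl carbon). The closest evidence is a 3.3-fold lower number from compound 1 to compound 2 (0.52 log units; beyond the scatter), a 6.9-fold lower number from compound 1 to compound 3 (0.84 log units; beyond the scatter) and a 2.1-fold lower number from compound 2 to compound 3 (0.32 log units; beyond the scatter). Among the compounds with values here, each of these exchanges only a group on an aromatic carbon, and no measured compound lacks that ring, so this is an extrapolation. A larger step towards a higher number is expected, estimated as an 8.4-fold higher number from compound 2 to compound 4 (0.93 log units; beyond the scatter). For compound 4 the estimated value is 800 nM, with an expected range of 150 nM to 4500 nM.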

Compound 4, half-maximal inhibitory concentration: 61 nM
Compound 4: the middle estimate sits 13-fold (1.12 log units) above what was measured; the measured number lies below the stated range.
By their numbers in this assay, from the lowest: compounds 3, 4 and 2 (each within the scatter of the next, the first and the last beyond it); then compound 1.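

In this assay, the aromatic ring on the carbonyl carbon proves unnecessary for a number in this range: replacing it with methyl gives a 1.6-fold lower number from compound 2 to compound 4 (0.19 log units; within the scatter), and the comparison with the 4-fluorophenyl compound gives a 1.4-fold higher number from compound 3 to compound 4 (0.13 log units; within the scatter). Only 4-(methoxycarbonyl)phenyl stands apart, with a 5.1-fold lower number from compound 1 to compound 4 (0.71 log units; beyond the scatter). Nothing available explains why the small methyl matches these larger groups.

Going by these compounds, it remains open whether a longer chain, such as butyl, would stay in this range on that carbonyl carbon. The same question applies to a chain ending in an amine or a carboxylic acid.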